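A few compounds are considered here, and "the series" means these few. Any claim that something is new, unique, unknown or untested is made for them only; others in the source may bear on it.

Measured so far:
compound 1, `Nc1cc(N)c2nc(-c3ccccc3)c(NCc3ccc(Cl)c(Cl)c3)nc2c1`, 4570 nM
compound 2, `COc1ccc(CNc2nc3cc(N)cc(N)c3nc2-c2ccccc2)cc1OC`, 20000 nM

In a functional assay on SF-539 cells (Homo sapiens) for inhibition, read by sulforhodamine B assay, with a stated time of 48 h (on this read-out lower numbers stand for stronger inhibition of growth and higher numbers for weaker inhibition of growth), compound 1 gives 4570 nM, and compound 2 gives 20000 nM. Compound 2 therefore stands at the highest of the two numbers, meaning the weaker growth inhibition. For the measured compounds named here, the only measured step that leads to it, a 4.4-fold higher number from compound 1 to compound 2 (0.64 log units; beyond the scatter), came from exchanging one aromatic substitution pattern for another on the saturated chain carbon bound to the ring nitrogen.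

Compound 3, `COc1cc(CNc2nc3cc(N)cc(N)c3nc2-c2ccccc2)cc(OC)c1OC`, differs from compound 2 by methoxy in place of hydrogen on an aromatic carbon. Going by the values given here, no measured pair shows what a further methoxy group does on this part of the molecule; the one measured step, a 4.4-fold higher number from compound 1 to compound 2 (0.64 log units; beyond the scatter), concerns a different exchange and only shows that changes on this ring can move the number. Among the compounds with values here, with that as the sole guide, compound 3 is expected to stay near compound 2, with a step that most likely does not go beyond the scatter and, if anything, points toward a higher number.

Compound 3 is estimated at 25000 nM in this assay, within a range from 8000 nM to 70000 nM. That estimate means an expected step of a 1.3-fold higher number from compound 2 to compound 3 (0.10 log units; within the scatter).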

Compound 3, concentration for 50% growth inhibition: 1350 nM
For compound 3 the middle estimate is 19-fold (1.27 log units) above the measured one; the measured number lies below the stated range.
By their numbers in this assay, from the lowest: compound 3; then compound 1; then compound 2.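

In this assay, placing one methoxy in place of hydrogen gives a 15-fold lower number from compound 2 to compound 3 (1.17 log units; beyond the scatter), which points to stronger inhibition of growth. This shows that a small addition on this aromatic carbon, ortho to a methoxy group and meta to a large group, can change the read-out strongly. The earlier step replaced the substituents of one ring with others, so it could not show what a single added group does at one place, whereas here the rest of the molecule stays the same. Nothing available here explains why this one methoxy group has so large an effect.

The compounds shown do not tell whether methoxy itself matters at this carbon, or whether an ethoxy group, a hydroxyl group or a fluorine atom there would give a similar number. They also do not tell whether the result depends on the two methoxy groups already on the ring, which a compound carrying a single methoxy group, or a third methoxy group set on a different ring carbon, could help to answer.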